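This account rests on a few compounds, and the source may have more. Where it says the series, first, only, none or still open, it means among the compounds named here.

In a physicochemical assay for solubility, in phosphate buffer, at pH 7.4 (on this read-out lower numbers stand for lower solubility and higher numbers for higher solubility), compound 1 `CC(=O)N[C@@H]1CCC[C@H](C(=O)Nc2cc(-c3cnn4c3CCCC4)c(F)cn2)C1` reads > 1000000 nM, which is a limit of the assay and not a number. Among the compounds with values here, compound 2 `CC(=O)N[C@@H]1CCC[C@H](C(=O)Nc2cc(-c3cnn4ccccc34)c(Cl)cn2)C1` gives 45000 nM, the only true number so far, so it is the one fixed point from which to judge the next compound.

That next compound is compound 3 `CC(=O)N[C@@H]1CCC[C@H](C(=O)Nc2cc(-c3cnn4c3CCC4)c(Cl)cn2)C1`, still unmeasured. Opposite the ring nitrogen, ortho to a chloro group, it carries a new group: a group of 8 heavy atoms (6 carbon, 2 nitrogen; one five-membered non-aromatic ring with 1 hetero atom, one five-membered aromatic ring with 2 hetero atoms) in place of a group of 9 heavy atoms (7 carbon, 2 nitrogen; one five-membered aromatic ring with 2 hetero atoms, one six-membered aromatic ring with 1 hetero atom), on an aromatic carbon. A six-membered aromatic ring with 1 hetero atom thus leaves, and a five-membered non-aromatic ring with 1 hetero atom enters.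

Within the data shown here, no measured step shows what this change does in this assay. Among the measured compounds shown here, the only guide is compound 1, for which the data show (the limit of > 1000000 nM in this assay, at which 1 of the 2 values shown sits). On that slender basis, a rise beyond the usual scatter is expected. The expected size of the move is a 5.6-fold higher number from compound 2 to compound 3 (0.74 log units; beyond the scatter). For compound 3 the estimated solubility is 250000 nM, with an expected range from 70000 nM to 900000 nM.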

Compound 3, solubility: 160000 nM
Beside the measured number, compound 3's estimate is 1.6-fold (0.19 log units) above it; the range from low to high includes it.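

In this assay, this position now has its first readable step: with the chloro group held constant, the group with one five-membered non-aromatic ring with 1 hetero atom and one five-membered aromatic ring with 2 hetero atoms takes the place of the group with one five-membered aromatic ring with 2 hetero atoms and one six-membered aromatic ring with 1 hetero atom, and this gives a 3.6-fold higher number from compound 2 to compound 3 (0.55 log units; beyond the scatter). The leaving and entering groups have the same counts of hydrogen-bond donors and acceptors and neither carries a net charge, so the step occurs without a difference in those counts, although this one pair cannot show which feature of the change accounts for it. Steps to compound 1 cannot be read, as it differs from compound 3 in more than one place and its reading is only a limit of the assay: the limit of > 1000000 nM in this assay, at which 1 of the 3 values shown sits.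

The compounds shown leave open whether a hydroxyl group or an amine on the five-membered non-aromatic ring would move the number further. They also leave open how this entering group would read with a bromo group or a methoxy group in place of the chloro group.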